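Trading piperidin-3-yl for 1-methylpyrrolidin-3-yl

This account rests on a few compounds, and the source may have more. Where it says the series, first, only, none or still open, it means among the compounds named here.

In a functional assay on MCF7 cells (Homo sapiens) for antiproliferative activity (a lower number here means a stronger inhibitor, a higher number a weaker inhibitor), compound 3 (`CC(C)=CCc1cc(C(=O)Nc2cc3ccc(OCC4CCCNC4)c(C)c3oc2=O)ccc1O`) gives 790 nM and serves as the starting point here. Compound 2 (`CC(C)=CCc1cc(C(=O)Nc2cc3ccc(OCCC4CCCCN4)c(C)c3oc2=O)ccc1O`) gives 710 nM and lies within the scatter of compound 3. Compound 1 (`CC(=O)Oc1ccc(C(=O)Nc2cc3ccc(OCC4CCN(C)C4)c(C)c3oc2=O)cc1CC=C(C)C`) gives 1880 nM as a higher number than compound 3, and that gap is beyond the scatter.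

The compound still waiting for its measurement is compound 4 (`CC(C)=CCc1cc(C(=O)Nc2cc3ccc(OCC4CCN(C)C4)c(C)c3oc2=O)ccc1O`). It carries 1-methylpyrrolidin-3-yl in place of piperidin-3-yl on a saturated chain carbon bound to an oxygen on an aromatic ring. Ring size changes here, and the nitrogen loses its hydrogen-bond donor count.

Going by the values given here, only one measured step touches this place: a 1.1-fold higher number from compound 2 to compound 3 (0.05 log units; within the scatter) where piperidin-3-yl replaces (piperidin-2-yl)methyl. Compound 4 also shares 1-methylpyrrolidin-3-yl with compound 1 at 1880 nM but differs from it elsewhere, so that number is only a loose guide towards the high side.

Going by these two observations, no step beyond the scatter is expected in this assay for this exchange. The estimated step is a 1.3-fold higher number from compound 3 to compound 4 (0.10 log units; within the scatter) and leans slightly towards a weaker inhibitor. Compound 4 is estimated at 1000 nM (expected range 450 nM to 2200 nM).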

Compound 4, half-maximal inhibitory concentration: 1550 nM
Estimate against measurement, compound 4: 1.6-fold (0.19 log units) below; the measured number falls inside the stated range.
By their numbers in this assay, from the lowest: compounds 2, 3, 4 and 1 (each within the scatter of the next, the first and the last beyond it).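

In this assay, going by these compounds alone, placing 1-methylpyrrolidin-3-yl where piperidin-3-yl stood gives a 2.0-fold higher number from compound 3 to compound 4 (0.29 log units; within the scatter), so changing the ring size and removing the hydrogen-bond donor together produces no step that can be told from the scatter, while the same group in place of (piperidin-2-yl)methyl gives a 2.2-fold higher number from compound 2 to compound 4 (0.34 log units; beyond the scatter), a modest step and the first at this position to pass the scatter. Within the data shown here, the new compound also gives the first direct reading at a second place, where hydrogen in place of acetyl on an oxygen on an aromatic ring gives a 1.2-fold lower number from compound 1 to compound 4 (0.08 log units; within the scatter), again a step that stays within the scatter. No supporting measurement is available to explain any of these steps.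

Ring size and the methyl on nitrogen change together in compound 4, so 1-methylpiperidin-3-yl or pyrrolidin-3-yl at this position would be needed to tell the two changes apart. As far as these compounds go, it also remains open whether an amine of another kind on this chain, such as morpholine or a simple dimethylamino group, would fall in the same range.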